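The compounds below may be only part of what the source reports. "The series", "measured", "known", "first", "only" and "open" are said of these compounds alone.

Measured so far:
compound 1, `O=[N+]([O-])c1cccc(CSc2nnc(-c3ccncc3)n2-c2ccccc2)c1`: 22000 nM
compound 2, `O=C(CSc1nnc(-c2ccncc2)n1-c1ccccc1)N/N=C/c1ccc(O)cc1`: > 50000 nM

Compound 1, `O=[N+]([O-])c1cccc(CSc2nnc(-c3ccncc3)n2-c2ccccc2)c1`, in a functional assay on HepG2 cells (Homo sapiens) for inhibition, read by MTT assay, with a stated time of 48 h (on this read-out higher numbers stand for weaker inhibition and lower numbers for stronger inhibition), gives 22000 nM. Compound 2, `O=C(CSc1nnc(-c2ccncc2)n1-c1ccccc1)N/N=C/c1ccc(O)cc1`, in this assay gives > 50000 nM, which is a limit of the assay rather than a number. Compound 2 thus stands at the edge of what this assay reports, as the limit of > 50000 nM in this assay, at which 1 of the 2 values shown sits, sets out, and compound 1 is the only one of the two with a measured number.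

Compound 3, `O=C(CSc1nnc(-c2ccncc2)n1-c1ccccc1)N/N=C/C=C/c1ccccc1`, differs from compound 2 in one place: 2-phenylethenyl in place of 4-hydroxyphenyl on a carbon with a double bond to nitrogen. Among the measured compounds shown here, no step between two measured compounds is known here, so the size of this change is not anchored by anything measured. The step of a number no higher from compound 2 to compound 3 (the limit leaves the size open) is expected to be small in either direction, or none beyond the usual scatter, since compound 2 already sits at the limit. Compound 3 is therefore estimated at 50000 nM in this assay, within a range from 15000 nM to 150000 nM, with a fair chance that only a limit is reported again.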

Compound 3, half-maximal inhibitory concentration: 8280 nM
The estimate for compound 3 lay 6.0-fold (0.78 log units) above the measured number; the whole stated range lies above it.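

The earlier compounds shown here offered no measured step, so nothing showed whether the group on a carbon with a double bond to nitrogen matters in this assay at all; 2-phenylethenyl in place of 4-hydroxyphenyl now brings an at least 6.0-fold lower number from compound 2 to compound 3 (0.78 log units; beyond the scatter) and shows that this place does respond to the group it carries. With the shared core unchanged, compound 3 gives 8280 nM in this assay and so brings this series of hydrazone-bearing compounds onto the measurable part of the scale. On these data alone, the true size of the step stays open because compound 2 has only a limit and not a number: the limit of > 50000 nM in this assay, at which 1 of the 3 values shown sits.

The swap changes several things at once: the hydroxyl oxygen leaves, and a double bond outside aromatic rings enters, so the compounds shown cannot tell which of these carries the step. A plain phenyl group, a saturated phenylethyl chain or a longer chain ending in an amine at this place would be the comparisons that could separate these changes.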